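Shifting the halogen on the phenyl of compound 2

The source may report more compounds than this note shows. Statements on the series, on what has been measured and on what is new or still open speak of the compounds shown alone.

In an ADME assay on L02 cells (Homo sapiens) for cytotoxicity, read by MTT assay, with a stated time of 24 h (on this read-out higher numbers stand for lower toxicity in this test and lower numbers for higher toxicity in this test), compound 1 `CC1(C)[C@H]2CC[C@]1(C)N(Cc1cn(-c3ccccc3C#N)nn1)C(=O)C2` gives 46100 nM and compound 2 `CC1(C)[C@H]2CC[C@]1(C)N(Cc1cn(-c3ccccc3Cl)nn1)C(=O)C2` gives 20100 nM, so compound 2 stands lowest of the two numbers. Compound 3 `CC1(C)[C@H]2CC[C@]1(C)N(Cc1cn(-c3cccc(Br)c3)nn1)C(=O)C2` differs from compound 2 by 3-bromophenyl in place of 2-chlorophenyl on an aromatic nitrogen. Among the compounds with values here, the one measured step, a 2.3-fold lower number from compound 1 to compound 2 (0.36 log units; beyond the scatter), concerns a different exchange on that phenyl and bears on this change only loosely. Within the data shown here, no step here exchanges one halogen for another, so no change beyond the scatter is expected, and the step of a 1.1-fold higher number from compound 2 to compound 3 (0.04 log units; within the scatter) is the estimate. Compound 3 is therefore expected to give 22000 nM, within 9000 nM to 50000 nM.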

Compound 3, half-maximal cytotoxic concentration: 10500 nM
Compound 3: middle estimate off by 2.1-fold (0.32 log units), on the high side, and the stated range covers the measured number.
By their numbers in this assay, from the lowest: compounds 3 and 2 (each within the scatter of the next); then compound 1.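

In this assay the exchange on the aromatic nitrogen gives a 1.9-fold lower number from compound 2 to compound 3 (0.28 log units; within the scatter), so 3-bromophenyl and 2-chlorophenyl are not told apart here, even though the halogen and its place on the phenyl change together. Set against 2-cyanophenyl, 3-bromophenyl gives a 4.4-fold lower number from compound 1 to compound 3 (0.64 log units; beyond the scatter), which leaves compound 1 apart from both halogen-bearing compounds. Nothing shown here explains these numbers. The compounds shown leave open whether the halogen and its place on the phenyl each matter alone, and how an amine or a carboxylic acid on that phenyl would read.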